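A few compounds are considered here, and "the series" means these few. Any claim that something is new, unique, unknown or untested is made for them only; others in the source may bear on it.

Measured so far: compound 1 `COC(=O)c1ccc(-c2cn(CCCC(=O)Nc3ccc(-c4ccccc4)cc3)nn2)cc1` at 330 nM; compound 2 `O=C(CCCn1cc(-c2ccc(C(F)(F)F)cc2)nn1)Nc1ccc(-c2ccccc2)cc1` at 19100 nM; compound 3 `COC(=O)c1ccc(-c2cn(CCCC(=S)Nc3ccc(C)cc3)nn2)cc1` at 50000 nM.

All three were tested in a functional assay on A549 cells (Homo sapiens) for inhibition, read by MTT assay, with a stated time of 72 h; a lower number here means a stronger inhibitor, a higher number a weaker inhibitor. Compound 1 and compound 2 share a core and differ in one place, (trifluoromethyl in place of methoxycarbonyl on an aromatic carbon); that change gave a 58-fold higher number from compound 1 to compound 2 (1.76 log units; beyond the scatter). Compound 4 `Cc1ccc(NC(=S)CCCn2cc(-c3ccc(C(F)(F)F)cc3)nn2)cc1` has not yet been measured. It stands to compound 3 as compound 2 stands to compound 1, the same change at the same place, (trifluoromethyl in place of methoxycarbonyl on an aromatic carbon). The difference between the two cores is not broken down here. Because the same change gave a 58-fold higher number from compound 1 to compound 2 (1.76 log units; beyond the scatter), the number for compound 4 is expected to move the same way, though compound 3 already stands at 50000 nM, the highest of the three. The estimated step from compound 3 to compound 4 is a 3.0-fold higher number from compound 3 to compound 4 (0.48 log units; beyond the scatter). Compound 4 is expected to give about 150000 nM, within 40000 nM to 2000000 nM.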

Compound 4, half-maximal inhibitory concentration: 5500 nM
Compound 4: middle estimate off by 27-fold (1.44 log units), on the high side, and the stated range ends above it.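

In this assay, putting trifluoromethyl in place of methoxycarbonyl gave a 9.1-fold lower number from compound 3 to compound 4 (0.96 log units; beyond the scatter), so the change did not carry over between the two cores and its direction reversed: the same change on two cores in this assay, a 58-fold higher number (1.76 log units; beyond the scatter) from compound 1 to compound 2 and a 9.1-fold lower number (0.96 log units; beyond the scatter) from compound 3 to compound 4, 530-fold (2.72 log units) apart, beyond the scatter of two such steps

For these two pairs, then, a step measured on one core is a poor guide to the same step on the other. The cores differ in more than one place, so these four compounds do not show which difference reverses the step, or why.

Going by these compounds, it remains open how a carboxylic acid or a nitrile in the same place would behave on each core. Also open, on these data alone, is what a core carrying only one of those differences would give, such as one that keeps the phenyl group of compound 1 but has the sulfur of compound 3.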